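From Compound 2 to Compound 4: Butyl for Hydrogen

The source may hold more compounds than are shown below. What is called first, only, known or untested is meant among the compounds shown, and "the series" means these compounds.

Measured in a functional assay on MCF7 cells (Homo sapiens) for cytotoxicity, read by MTT assay, with a stated time of 72 h; on this read-out lower numbers stand for stronger inhibition and higher numbers for weaker inhibition:
compound 1, `O=C(CSC(=S)N[C@H]1CCOC1=O)Nc1ccccc1F`: 28600 nM
compound 2, `O=C(CSC(=S)N[C@H]1CCOC1=O)Nc1ccccc1`: > 128000 nM
compound 3, `O=C(CSC(=S)N[C@H]1CCOC1=O)Nc1ccccc1Cl`: 90800 nM

Compound 2 carries the shared core with an unsubstituted six-membered aromatic ring of carbon only. Its entry in this assay is a limit of the assay and not a number, and it sits at the limit of > 128000 nM in this assay, at which 1 of the 3 values shown sits. Compound 4, `CCCCc1ccc(NC(=O)CSC(=S)N[C@H]2CCOC2=O)cc1`, differs from compound 2 by butyl in place of hydrogen on an aromatic carbon.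

Within the data shown here, the steps that bear on this change are those in which a group replaces hydrogen on the same ring. Going one way, an at least 1.4-fold lower number from compound 2 to compound 3 (0.14 log units; that floor lies within the scatter). Going the other way, an at least 4.4-fold higher number from compound 1 to compound 2 (0.65 log units; beyond the scatter). Between the two halogens, a 3.2-fold higher number from compound 1 to compound 3 (0.50 log units; beyond the scatter). Compound 1 with fluoro thus gave a lower number than compound 2 beyond the scatter, while for chloro in compound 3 the floor lies within the scatter.

Butyl is a different kind of group from either halogen, and no step with it has been measured, so the size of the step is uncertain. A lowering is nevertheless expected, as an at least 2.1-fold lower number from compound 2 to compound 4 (0.32 log units; beyond the scatter). Compound 4 is therefore estimated to give about 60000 nM in this assay, within the range 15000 nM to 200000 nM, with a fair chance that only a limit is reported again.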

Compound 4, half-maximal inhibitory concentration: 40200 nM
Compound 4: the middle estimate sits 1.5-fold (0.17 log units) above what was measured, and the stated range covers the measured number.
By their numbers in this assay, from the lowest: compounds 1 and 4 (each within the scatter of the next); then compound 3. At a limit, above all of these: compound 2.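

In this assay, butyl in place of hydrogen on an aromatic carbon, para to a large group, gives an at least 3.1-fold lower number from compound 2 to compound 4 (0.50 log units; beyond the scatter). Until now, only a halogen had been seen to replace hydrogen on this ring, and only fluoro gave a step beyond the scatter, an at least 4.4-fold higher number from compound 1 to compound 2 (0.65 log units; beyond the scatter), while for chloro the floor stayed within it, an at least 1.4-fold lower number from compound 2 to compound 3 (0.14 log units; that floor lies within the scatter); compound 4 shows that a group of carbon alone, with no ring, no hydrogen-bond donors and no hydrogen-bond acceptors, can also give a step beyond the scatter when it stands para to a large group. Compound 2 stands at a limit of the assay and not at a number, so the new step is a floor and its full size cannot be read: the limit of > 128000 nM in this assay, at which 1 of the 4 values shown sits.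

The compounds shown leave open whether this lowering belongs to butyl itself or would also come with a methyl group, a longer chain such as hexyl, an amine or a carboxylic acid on the same carbon. They also leave open how fluoro or chloro would behave para to a large group, so the effect of the group cannot yet be separated from that of its place on the ring.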